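Removing one methoxy group on a cell-based cytotoxicity read-out

This account rests on a few compounds, and the source may have more. Where it says the series, first, only, none or still open, it means among the compounds named here.

Compound 1 `COC(=O)c1c(-c2ccc([N+](=O)[O-])cc2)oc2ccccc2c1=O`: > 25 ug/mL
Compound 2 `COC(=O)c1c(-c2ccc([N+](=O)[O-])cc2)oc2cc(OC)ccc2c1=O`: > 25 ug/mL
Compound 3 `COc1cc(-c2oc3ccccc3c(=O)c2C(=O)O)cc(OC)c1OC`: > 25 ug/mL

In a functional assay on A549 cells (Homo sapiens) for cytotoxicity, read by MTT assay, with a stated time of 6 days (on this read-out higher numbers stand for an effect only at larger amounts of compound and lower numbers for an effect already at smaller amounts), none of the three measured compounds gave a number. The value of compound 1 is a limit of the assay. The value of compound 2 is likewise a limit. The value of compound 3 is also a limit. Compound 2 and compound 1 differ by hydrogen in place of methoxy on an aromatic carbon, and the step that the two limits leave unreadable from compound 2 to compound 1 cannot be read, since (the limit of > 25 ug/mL in this assay, at which 3 of the 3 values shown sit).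

Compound 4 `COc1cc(OC)cc(-c2oc3ccccc3c(=O)c2C(=O)O)c1` is not yet measured. It differs from compound 3 by hydrogen in place of methoxy on an aromatic carbon. This is the same kind of change as that from compound 2 to compound 1, but the surroundings differ: there the place is part of a fused or bridged system of two rings, meta to a fused ring and para to a fused ring, whereas here it is ortho to two methoxy groups and para to a large group. How the core of compound 3 differs from that of compound 2 is not broken down here.

With every measured value sitting at the limit, the step that the limit leaves unreadable from compound 3 to compound 4 is expected to be small, resting on compound 3 giving > 25 ug/mL. Compound 4 is therefore estimated at 35 ug/mL, most likely again reported only as a limit.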

Compound 4, concentration for half-maximal effect: > 25 ug/mL
Compound 4: only a limit was reported; the forecaster's own chance of this, stated with the estimate: 80%; the middle value lies beyond the limit too.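

For the compounds shown here, compound 3 and compound 4 both stand at a limit in this assay, so no step between them can be read: the limit of > 25 ug/mL in this assay, at which 4 of the 4 values shown sit.

The compounds shown leave open whether exchanging methoxy for hydrogen changes cytotoxicity at all, and at what amount any of the four would act on these cells.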